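Two Measured Amides and a Third Awaiting Its Number

This account rests on a few compounds, and the source may have more. Where it says the series, first, only, none or still open, it means among the compounds named here.

In a functional assay on MCF7 cells (Homo sapiens) for antiproliferative activity (a lower number here means a stronger inhibitor, a higher number a weaker inhibitor), compound 1 `CC(=O)Oc1ccc(C(=O)Nc2cc3ccc(Oc4ccc(C(C)(C)C)cc4)c(C)c3oc2=O)cc1CC=C(C)C` gives 75000 nM.
Compound 2 `COc1ccc(Cc2ccc3cc(NC(=O)c4ccc(OC(C)=O)c(CC=C(C)C)c4)c(=O)oc3c2C)cc1` gives 11500 nM.

Among the compounds with values here, compound 2 stands as the lower of the two numbers; the single measured step, a 6.5-fold lower number from compound 1 to compound 2 (0.81 log units; beyond the scatter), separates them. Compound 3 `COCOc1ccc(Cc2ccc3cc(NC(=O)c4ccc(OC(C)=O)c(CC=C(C)C)c4)c(=O)oc3c2C)cc1` differs from compound 2 by methoxy in place of hydrogen on a saturated chain carbon bound to an oxygen on an aromatic ring. Within the data shown here, that one measured step touched a different part of the molecule, so no measured step bears on this change. The expectation is therefore no step beyond the scatter, a 1.0-fold higher number from compound 2 to compound 3 (0.02 log units; within the scatter). Compound 3 is estimated at 12000 nM, with a range from 4000 nM to 40000 nM.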

Compound 3, half-maximal inhibitory concentration: 22700 nM
Beside the measured number, compound 3's estimate is 1.9-fold (0.28 log units) below it; measured number inside the range.
By their numbers in this assay, from the lowest: compounds 2 and 3 (each within the scatter of the next); then compound 1.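

Placing methoxy on the saturated chain carbon, which turns 4-methoxyphenyl into 4-(methoxymethoxy)phenyl, gives in this assay a 2.0-fold higher number from compound 2 to compound 3 (0.30 log units; within the scatter) and so does not separate the two compounds. The 4-(methoxymethoxy)benzyl group still differs from 4-(tert-butyl)phenoxy on the aromatic carbon, with a 3.3-fold lower number from compound 1 to compound 3 (0.52 log units; beyond the scatter) in the same assay. No outside measurement is available to explain either step.

Open, as far as these compounds go, is whether a longer chain, such as ethoxyethoxy, or an amine in this place would give a step beyond the scatter.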